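The compounds below may be only part of what the source reports. "The series", "measured", "known", "first", "only" and "open" are said of these compounds alone.

Measured compounds:
- compound 1 `CCOc1ccc(Cc2nnc(CN(c3cccc(Cl)c3C)S(=O)(=O)c3ccc(C)cc3)o2)cc1`, 50.1 nM in a functional assay on CHO cells for antagonist activity at prostaglandin E2 receptor EP1 subtype (Homo sapiens), read by FLIPR and calcium flux; a higher number here means a weaker inhibitor, a lower number a stronger inhibitor
- compound 2 `CCc1ccccc1N(Cc1nnc(CNc2ccc(OC)cc2)o1)S(=O)(=O)c1ccc(C)cc1`, 794 nM in this assay

Compound 2 stands highest of the two numbers; compound 1 sits well apart, beyond the scatter. Compound 3 `COc1ccc(NCc2nnc(CN(c3cccc(Cl)c3C)S(=O)(=O)c3ccc(C)cc3)o2)cc1` is not yet measured. Compound 3 differs from compound 2 by 3-chloro-2-methylphenyl in place of 2-ethylphenyl on a sulfonamide nitrogen. Going by the values given here, compound 1 bears the same aryl group on the sulfonamide nitrogen but also differs from compound 2 elsewhere, so no step for this change alone is on hand. A moderate drop in the number is expected, a 2.6-fold lower number from compound 2 to compound 3 (0.42 log units; beyond the scatter), with wide uncertainty. Compound 3 is estimated at 300 nM, within 80 nM to 1200 nM.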

Compound 3, inhibition constant: 79.4 nM
Compound 3: the middle estimate sits 3.8-fold (0.58 log units) above what was measured; measured number outside the range, below it.
By their numbers in this assay, from the lowest: compounds 1 and 3 (each within the scatter of the next); then compound 2.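

On a sulfonamide nitrogen, 3-chloro-2-methylphenyl in place of 2-ethylphenyl gives a 10-fold lower number from compound 2 to compound 3 (1.00 log units; beyond the scatter) in this assay, a single-place reading of this position that the earlier pair did not offer. With that aryl group held constant, (4-methoxyphenyl)amino in place of 4-ethoxyphenyl on a saturated chain carbon bound to an aromatic carbon gives a 1.6-fold higher number from compound 1 to compound 3 (0.20 log units; within the scatter), so the two groups are not told apart here. Nothing on hand bears on the origin of either step.

Open, from the compounds shown here alone, is how 3-chlorophenyl or 2-methylphenyl would read on the sulfonamide nitrogen, which would separate the chlorine from the methyl. Also open, going by these compounds, is whether a carboxylic acid or an amine on the 4-ethoxyphenyl ring is tolerated.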